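The source may hold more compounds than are shown below. What is called first, only, known or untested is meant among the compounds shown, and "the series" means these compounds.

Of the compounds shown here, three sharing one core have been measured in a functional assay on HCT-116 cells (Homo sapiens) for cytotoxicity, read by MTT assay, with a stated time of 72 h; on this read-out higher numbers stand for weaker inhibition and lower numbers for stronger inhibition. Compound 1 `CN1CCN(Cc2nnc(-c3cc(S(N)(=O)=O)c(SCc4ccccc4)cc3Cl)o2)CC1` gives 75000 nM. Compound 2 `[N-]=[N+]=NCc1nnc(-c2cc(S(N)(=O)=O)c(SCc3ccccc3)cc2Cl)o1` gives 100000 nM, and compound 3 `CCOC(=O)c1cn(Cc2nnc(-c3cc(S(N)(=O)=O)c(SCc4ccccc4)cc3Cl)o2)nn1` gives 108000 nM. These three numbers sit close together: a 1.3-fold higher number from compound 1 to compound 2 (0.12 log units; within the scatter), a 1.4-fold higher number from compound 1 to compound 3 (0.16 log units; within the scatter) and a 1.1-fold higher number from compound 2 to compound 3 (0.03 log units; within the scatter) each fall within the usual scatter of repeated measurements, so compound 3 cannot be set apart from the other two on the numbers shown. Compound 4 `COc1ccc(-c2cn(Cc3nnc(-c4cc(S(N)(=O)=O)c(SCc5ccccc5)cc4Cl)o3)nn2)cc1` has not yet been measured. It differs from compound 3 in one place: 4-methoxyphenyl in place of ethoxycarbonyl on an aromatic carbon. Within the data shown here, no measured step touches this part of the molecule directly; the three known steps all exchange the group on the saturated chain carbon, and every one of them stayed within the scatter. Among the measured compounds shown here, the numbers so far give no reason to expect a change beyond the scatter in this assay, and the expected step of a 1.1-fold lower number from compound 3 to compound 4 (0.03 log units; within the scatter) is therefore small. Compound 4 is expected to give about 100000 nM, with a likely range from 40000 nM to 250000 nM.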

Compound 4, half-maximal inhibitory concentration: 190000 nM
Estimate against measurement, compound 4: 1.9-fold (0.28 log units) below; the range from low to high includes it.
By their numbers in this assay, from the lowest: compounds 1, 2, 3 and 4 (each within the scatter of the next, the first and the last beyond it).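

In this assay, 4-methoxyphenyl in place of ethoxycarbonyl on an aromatic carbon of the five-membered aromatic ring with 3 nitrogen gives a 1.8-fold higher number from compound 3 to compound 4 (0.25 log units; within the scatter). Among these compounds, this is the first look at this position, as the earlier steps all exchanged the group on the saturated chain carbon, and it shows that a group with 8 heavy atoms and a six-membered aromatic ring can replace one with 5 heavy atoms and no ring while the step stays within the scatter. No supporting measurement bears on the size of this step. A single step cannot show whether other groups at this position, such as a carboxylic acid, an amine or a longer alkyl chain, would also stay within the scatter. It also leaves open what a plain phenyl, without the methoxy group, would give.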